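This account rests on a few compounds, and the source may have more. Where it says the series, first, only, none or still open, it means among the compounds named here.

Compound 3 `CCNC(=O)Nc1cccc(S(=O)(=O)Oc2ccccc2CC)c1` was tested in a functional assay on M21 cells (Homo sapiens) for cytotoxicity, read by sulforhodamine B assay, with a stated time of 48 h (a lower number here means a stronger inhibitor, a higher number a weaker inhibitor), where compound 3 gives 30000 nM. Two related compounds were measured alongside it. Compound 1 `O=C(NCCCCl)Nc1cccc(S(=O)(=O)Oc2ccc(O)cc2)c1` gives 49000 nM, and compound 2 `CCNC(=O)Nc1cccc(S(=O)(=O)Oc2ccccc2C)c1` gives 51000 nM; all three numbers lie within the usual scatter of one another, so compound 3 is not set apart from either of them. Going by the values given here, the one single-site step among them, a 1.7-fold lower number from compound 2 to compound 3 (0.23 log units; within the scatter), also stays within the scatter.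

Compound 4 `CCNC(=O)Nc1cccc(S(=O)(=O)Oc2ccc(O)cc2)c1` differs from compound 3 by 4-hydroxyphenyl in place of 2-ethylphenyl on an oxygen. Among the compounds with values here, this change touches the same ring that was altered between compound 2 and compound 3, where the step was small, and it brings in the same 4-hydroxyphenyl that compound 1 carries at 49000 nM; no single-site step is recorded between compound 1 and compound 3, so only their two values can be compared. Nothing here points to a change beyond the scatter, so the step of a 1.3-fold higher number from compound 3 to compound 4 (0.12 log units; within the scatter) is expected to be small. Compound 4 is therefore estimated at 40000 nM, with a likely range from 15000 nM to 100000 nM.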

Compound 4, half-maximal inhibitory concentration: 42000 nM
The estimate for compound 4 lay 1.1-fold (0.02 log units) below the measured number; measured number inside the range.
By their numbers in this assay, from the lowest: compounds 3, 4, 1 and 2 (each within the scatter of the next).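

In this assay, the ring on the oxygen bound to the sulfonyl sulfur can change from an alkyl-bearing phenyl to a hydroxy-bearing one without a clear effect: 4-hydroxyphenyl in place of 2-ethylphenyl gives (a 1.4-fold higher number from compound 3 to compound 4 (0.15 log units; within the scatter)), and in place of 2-methylphenyl gives (a 1.2-fold lower number from compound 2 to compound 4 (0.08 log units; within the scatter)). Going by these compounds alone, the chain at the other end of the molecule can now be read for the first time, and hydrogen in place of chloromethyl on a saturated chain carbon, two bonds along the chain from an amide-type nitrogen, gives (a 1.2-fold lower number from compound 1 to compound 4 (0.07 log units; within the scatter)), so this change also stays within the scatter. No measurement shown explains why these steps are so small.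

Neither site has yet produced a step beyond the scatter. Going by these compounds, it remains open whether a carboxylic acid or an amine on the ring bound to that oxygen, or a phenyl ring at the end of the chain, would do so.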